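The source may hold more compounds than are shown below. What is called first, only, known or untested is meant among the compounds shown, and "the series" means these compounds.

Measured compounds:
- compound 1, `CCNc1nccc2c1ncn2C1O[C@H](CO)[C@@H](O)[C@H]1O`, gives 4% in a functional assay (Homo sapiens) for inhibition of Nucleic Acid, tested at 100 uM; on this read-out lower numbers stand for less inhibition and higher numbers for more inhibition at the one concentration tested (going by the name of the read-out)
- compound 2, `OC[C@H]1OC(n2cnc3c(NCc4ccccc4)nccc32)[C@H](O)[C@@H]1O`, gives 32% in this assay

Within the data shown here, compound 2 holds the higher of the two numbers; its nearest neighbour is compound 1, and the only recorded step runs a number 28 percentage points higher from compound 1 to compound 2 (beyond the scatter), a phenyl in place of methyl on a saturated chain carbon bound to a nitrogen on an aromatic ring. Compound 3, `OC[C@H]1OC(n2cnc3c(S)nccc32)[C@H](O)[C@@H]1O`, takes a different route: sulfanyl in place of benzylamino on an aromatic carbon. Among the measured compounds shown here, no measured step covers sulfanyl in place of benzylamino directly, so the step from compound 1 to compound 2 bears only indirectly: the benzylamino group that leaves is the one whose phenyl accompanied the rise from compound 1 to compound 2. With that group gone entirely, the number is expected to fall back to the low level of compound 1, or lower, so the estimated step is a number 26 percentage points lower from compound 2 to compound 3 (beyond the scatter). Compound 3 is expected to give about 6% in this assay, within 0% to 22%.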

Compound 3, a percentage reported as inhibition, at one concentration (the size of the read-out at that concentration, not a potency): 6%
Compound 3: the middle estimate sits on the measured number at the digits printed; measured number inside the range.
By their numbers in this assay, from the lowest: compounds 1 and 3 (each within the scatter of the next); then compound 2.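

In this assay the change on this aromatic carbon, next to the ring nitrogen, gives a number 26 percentage points lower from compound 2 to compound 3 (beyond the scatter) and so shows that compound 2's higher number does not persist once benzylamino gives way to sulfanyl. Sulfanyl and ethylamino do not separate at this position, with a number 2 percentage points higher from compound 1 to compound 3 (within the scatter), so among these three compounds only benzylamino stands apart, whether the atom bound to the aromatic carbon is nitrogen or sulfur. Nothing available gives a reason for either step.

From the compounds shown here alone, what remains open is whether the number in this assay follows the aromatic ring of the benzylamino group or the nitrogen linking it to the core. A cyclohexylmethylamino group and a benzylsulfanyl group at this carbon would separate those two readings, and a phenethylamino chain would add the question of chain length.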